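Replacing Isopropyl with Cyclohexylmethyl on the Sulfonyl Sulfur

The compounds below may be only part of what the source reports. "The series", "measured", "known", "first", "only" and "open" are said of these compounds alone.

Three measured compounds share one core and differ only in the group on an amine nitrogen in a ring. In a functional assay on CHO-K1 cells for agonist activity at Glucose-dependent insulinotropic receptor (Homo sapiens), read by a luciferase reporter, with a stated time of 5 h (on this read-out lower numbers stand for an effect already at smaller amounts and higher numbers for an effect only at larger amounts of compound), compound 1 `CC(C)NC(=O)CN1CCN(c2ccc(OCC3CCN(C(=O)OC(C)C)CC3)cn2)CC1` reaches only a limit, > 10000 nM. Compound 2 `CC(C)OC(=O)N1CCC(COc2ccc(N3CCN(C(=O)c4ccco4)CC3)nc2)CC1` gives 1900 nM in this assay, and compound 3 `CC(C)OC(=O)N1CCC(COc2ccc(N3CCN(S(=O)(=O)C(C)C)CC3)nc2)CC1` gives 300 nM. The steps read an at least 5.2-fold lower number from compound 1 to compound 2 (0.72 log units; beyond the scatter), an at least 33-fold lower number from compound 1 to compound 3 (1.52 log units; beyond the scatter) and a 6.3-fold lower number from compound 2 to compound 3 (0.80 log units; beyond the scatter), so compound 3 holds the lowest of the two numbers. Compound 4 `CC(C)OC(=O)N1CCC(COc2ccc(N3CCN(S(=O)(=O)CC4CCCCC4)CC3)nc2)CC1` keeps the sulfonyl group and alters only what hangs on it: cyclohexylmethyl in place of isopropyl on a sulfonyl sulfur. Going by the values given here, none of the measured steps changes a substituent on the sulfonyl sulfur; each swaps the whole group on the nitrogen, so they offer no direct guide. The step is expected to stay small, no change at the digits printed from compound 3 to compound 4 (within the scatter). Compound 4 is estimated at 300 nM, between 80 nM and 1200 nM.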

Compound 4, half-maximal effective concentration: 90 nM
Compound 4: middle estimate off by 3.3-fold (0.52 log units), on the high side, and the stated range covers the measured number.
By their numbers in this assay, from the lowest: compound 4; then compound 3; then compound 2. At a limit, above all of these: compound 1.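

The substituent on the sulfonyl sulfur is itself a place that moves the number: with everything else unchanged, cyclohexylmethyl in place of isopropyl gives a 3.3-fold lower number from compound 3 to compound 4 (0.52 log units; beyond the scatter). The earlier steps shown here swapped the whole group on the nitrogen, and the new sulfonamide widens the distance to both other groups, with a 21-fold lower number from compound 2 to compound 4 (1.32 log units; beyond the scatter) and an at least 110-fold lower number from compound 1 to compound 4 (2.04 log units; beyond the scatter). Compound 1 stands at a limit, not a number, so that last step is only a bound: the limit of > 10000 nM in this assay, at which 1 of the 4 values shown sits.

Only two groups on the sulfur are shown, so whether the ring or simply the larger carbon count matters stays open. A straight hexyl chain or a phenyl on the sulfur would separate the two.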